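Pentyl to tert-butyl: an expected small step

The source may report more compounds than this note shows. Statements on the series, on what has been measured and on what is new or still open speak of the compounds shown alone.

In a functional assay on SW1573 cells (Homo sapiens) for antiproliferative activity, read by sulforhodamine B assay, with a stated time of 48 h (a lower number here means a stronger inhibitor of growth, a higher number a weaker inhibitor of growth), compound 1 (`CCOC(=O)C#CC(O/C=C/C(=O)OCC)C(C)C`) gives 2800 nM and compound 2 (`CCCCCC(C#CC(=O)OC)O/C=C/C(=O)OC`) gives 1700 nM. These two numbers lie within the scatter of each other, so compound 2 cannot be told apart from compound 1. Compound 3 (`COC(=O)C#CC(O/C=C/C(=O)OC)C(C)(C)C`) carries tert-butyl in place of pentyl on a saturated chain carbon bound to an oxygen on an unsaturated carbon and a triple-bonded carbon. Within the data shown here, no measured step covers this change. The expected step, a 1.3-fold higher number from compound 2 to compound 3 (0.11 log units; within the scatter), stays within the scatter, with no clear direction. The estimate for compound 3 is 2200 nM, with an expected range of 900 nM to 5500 nM.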

Compound 3, concentration for 50% growth inhibition: 3000 nM
Beside the measured number, compound 3's estimate is 1.4-fold (0.13 log units) below it; low and high end bracket the measured number.
By their numbers in this assay, from the lowest: compounds 2, 1 and 3 (each within the scatter of the next).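

Among these compounds, replacing pentyl with tert-butyl on a saturated chain carbon bound to an oxygen on an unsaturated carbon and a triple-bonded carbon gives, in this assay, a 1.8-fold higher number from compound 2 to compound 3 (0.25 log units; within the scatter), the first measured step at this position. The two groups therefore cannot be told apart here. Nothing measured bears on the reason for this result. Going by these compounds, it remains open whether a phenyl ring or an amine at this position would give a step beyond the scatter. A single step also leaves open whether the same change would read alike on a different ester.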